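The source may hold more compounds than are shown below. What is called first, only, known or untested is meant among the compounds shown, and "the series" means these compounds.

Measured compounds and their values in an ADME assay on cells (Hepatocyte, Rattus norvegicus) for metabolic stability, using equilibrium dialysis; on this read-out higher numbers stand for fast clearance and lower numbers for slow clearance:

compound 1, `CC(=O)N[C@@H]1CCC[C@H](C(=O)Nc2cc(-c3cnc(C)n3C(C)C)ccn2)C1`, 7.4 uL/min
compound 2, `CC(=O)N[C@@H]1CCC[C@H](C(=O)Nc2cc(-c3cnn4c3CCCC4)c(Cl)cn2)C1`, 46 uL/min
compound 3, `CC(=O)N[C@@H]1CCC[C@H](C(=O)Nc2cc(-c3cnc4n3CCC4)c(Cl)cn2)C1`, 19 uL/min

Compound 3 stands second highest of the three numbers in this assay; the nearest value is that of compound 2, the furthest that of compound 1, and both gaps lie beyond the scatter.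

Compound 4, `CC(=O)N[C@@H]1CCC[C@H](C(=O)Nc2cc(-c3cnn4c3NCCC4)c(Cl)cn2)C1`, is not yet measured. It differs from compound 3 as follows: a group of 9 heavy atoms (6 carbon, 3 nitrogen; one five-membered aromatic ring with 2 hetero atoms, one six-membered non-aromatic ring with 2 hetero atoms) in place of a group of 8 heavy atoms (6 carbon, 2 nitrogen; one five-membered non-aromatic ring with 1 hetero atom, one five-membered aromatic ring with 2 hetero atoms), on an aromatic carbon. Among the compounds with values here, the only measured step that touches the same position is a 2.4-fold lower number from compound 2 to compound 3 (0.38 log units; beyond the scatter), where a six-membered non-aromatic ring gave way to a five-membered one and the number fell modestly. Within the data shown here, compound 4 goes the other way in ring size, so a modest rise is the natural expectation, though the added hydrogen-bond donor has no precedent among the measured compounds.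

For compound 4 the expected value in this assay is 30 uL/min, with a range of 12 uL/min to 70 uL/min. This estimate implies a step of a 1.6-fold higher number from compound 3 to compound 4 (0.20 log units; within the scatter), modest and likely at the edge of the scatter.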

Compound 4, intrinsic clearance in a liver preparation (reported as CLH), per the amount of preparation that the assay uses: 10 uL/min
Beside the measured number, compound 4's estimate is 3.0-fold (0.48 log units) above it, and the stated range ends above it.
By their numbers in this assay, from the lowest: compounds 1, 4 and 3 (each within the scatter of the next, the first and the last beyond it); then compound 2.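

In this assay, the six-membered non-aromatic ring no longer goes with the high number: with the second hetero atom in that ring, a 4.6-fold lower number from compound 2 to compound 4 (0.66 log units; beyond the scatter) lies beyond the scatter, at the same ring size. Against the five-membered ring, a 1.9-fold lower number from compound 3 to compound 4 (0.28 log units; within the scatter) stays within the scatter, so ring size alone does not set the number at this position on the ring, opposite the ring nitrogen. No measurement shown gives a reason for either step.

As far as these compounds go, it remains open whether the ring nitrogen itself or its hydrogen-bond donor goes with the step from the ring with one hetero atom. A methyl group on that nitrogen, or an oxygen atom in its place, would separate the two.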